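The source may report more compounds than this note shows. Statements on the series, on what has been measured and on what is new or still open speak of the compounds shown alone.

Measured in an assay on cells for inhibition of protein deacetylase HDAC6 (Homo sapiens), read by fluorescence, with stated times of 15 min and 60 min; a higher number here means a weaker inhibitor, a lower number a stronger inhibitor: compound 1 `O=C(NO)c1ccc(Cn2nc(-c3ccc(F)cc3)cc2Cc2ccccc2)cc1` gives 326 nM; compound 2 `Cc1cc(-c2ccc(F)cc2)nn1Cc1ccc(C(=O)NO)cc1` gives 8 nM.

Compound 2 stands lowest of the two numbers, the nearest being compound 1 at the step of a 41-fold lower number from compound 1 to compound 2 (1.61 log units; beyond the scatter). Compound 3 `CCc1cc(-c2ccc(F)cc2)nn1Cc1ccc(C(=O)NO)cc1` differs from compound 2 by methyl in place of hydrogen on a saturated chain carbon bound to an aromatic carbon. For the measured compounds named here, the only measured step at this place is a 41-fold lower number from compound 1 to compound 2 (1.61 log units; beyond the scatter), where a phenyl entering gave a large rise in number; a single carbon is a much smaller addition, so a small rise at most is expected, as the step of a 1.8-fold higher number from compound 2 to compound 3 (0.24 log units; within the scatter). For compound 3 in this assay the estimate is 14 nM, range 6 nM to 40 nM.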

Compound 3, half-maximal inhibitory concentration: 35 nM
Estimate against measurement, compound 3: 2.5-fold (0.40 log units) below; the range from low to high includes it.
By their numbers in this assay, from the lowest: compound 2; then compound 3; then compound 1.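

In this assay, methyl in place of hydrogen on this saturated chain carbon already costs potency, with a 4.4-fold higher number from compound 2 to compound 3 (0.64 log units; beyond the scatter), so even one added carbon registers here. Methyl in place of phenyl recovers only part of the loss, with a 9.3-fold lower number from compound 1 to compound 3 (0.97 log units; beyond the scatter), and the number rises in the order hydrogen, methyl, phenyl across these three compounds. Nothing available bears on the reason for this order.

Open, from the compounds shown here alone, is whether a longer chain such as propyl would continue the order, and how an amine or a carboxylic acid at this place would read.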